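Isopropyl for methyl on the amide of compound 2

The source may hold more compounds than are shown below. What is called first, only, known or untested is meant among the compounds shown, and "the series" means these compounds.

Of the compounds shown here, two have been measured in an assay on NIH3T3 cells for binding affinity to melatonin receptor type 1A (Homo sapiens); on this read-out higher numbers stand for weaker inhibition and lower numbers for stronger inhibition. Compound 1 `CCNC(=O)NC[C@@H]1C[C@H]1c1cccc2oc(CCCCc3ccccc3)cc12` gives 33 nM, and compound 2 `CC(=O)NCCCc1cccc2oc(CCCCc3ccccc3)cc12` gives 19 nM; the two numbers lie within the usual scatter of each other, so neither can be called the stronger binder. Compound 3 `CC(C)C(=O)NCCCc1cccc2oc(CCCCc3ccccc3)cc12` differs from compound 2 in one place: isopropyl in place of methyl on a carbonyl carbon. Among the measured compounds shown here, no measured pair shows the effect of such a change here. The step from compound 2 to compound 3 in this assay is expected to be small, a 1.3-fold higher number from compound 2 to compound 3 (0.12 log units; within the scatter), not beyond the scatter. Compound 3 is therefore estimated at 25 nM, between 8 nM and 80 nM.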

Compound 3, inhibition constant: 3.7 nM
The estimate for compound 3 lay 6.8-fold (0.83 log units) above the measured number; measured number below the stated range.
By their numbers in this assay, from the lowest: compound 3; then compounds 2 and 1 (each within the scatter of the next).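

In this assay, the group on this carbonyl carbon, whose other neighbour is an amide-type nitrogen, proves to matter: isopropyl in place of methyl gives a 5.1-fold lower number from compound 2 to compound 3 (0.71 log units; beyond the scatter). The position therefore accepts the three-carbon isopropyl group, and binding gets stronger with it rather than being lost. No available evidence bears on what lies behind this step. The compounds shown leave open whether a tert-butyl, a cyclopropyl or a longer chain on the same carbonyl carbon would go further or reverse the step.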